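Replacing the fluorinated nitrile in compound 3 with a sulfur group

The source may hold more compounds than are shown below. What is called first, only, known or untested is meant among the compounds shown, and "the series" means these compounds.

In a functional assay on CHO-K1 cells for agonist activity at Glucose-dependent insulinotropic receptor (Homo sapiens), read by a luciferase reporter, with a stated time of 5 h (a lower number here means that less compound is needed, a higher number that more compound is needed for the effect), compound 3 `CC(C)OC(=O)N1CCC(Oc2ncnc3c2CCN3c2ccc(C#N)c(F)c2)CC1` gives 398 nM, the highest of the three numbers measured. Compound 1 `CC(C)OC(=O)N1CCC(Oc2ncnc3c2CCN3c2ccc(S(C)(=O)=O)cc2)CC1` gives 126 nM and compound 2 `CC(C)OC(=O)N1CCC(Oc2ncnc3c2CCN3c2ccc(C#N)cc2F)CC1` gives 63.1 nM. The step of a 6.3-fold higher number from compound 2 to compound 3 (0.80 log units; beyond the scatter) is the larger one, and a 3.2-fold higher number from compound 1 to compound 3 (0.50 log units; beyond the scatter) is the smaller; a 2.0-fold lower number from compound 1 to compound 2 (0.30 log units; within the scatter) lies within the scatter.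

Compound 4 `CC(C)OC(=O)N1CCC(Oc2ncnc3c2CCN3c2ccc([S+]([O-])N(C)C)cc2)CC1` has not been measured. It differs from compound 3 by a group of 11 heavy atoms (8 carbon, 1 nitrogen, 1 oxygen, 1 sulfur; one six-membered aromatic ring of carbon only) in place of a group of 9 heavy atoms (7 carbon, 1 nitrogen, 1 fluorine; one six-membered aromatic ring of carbon only), on a nitrogen on an aromatic ring in a ring. The group that enters has no common name; like the 4-(methylsulfonyl)phenyl of compound 1 it carries a sulfur and an oxygen and no fluorine, so among the measured steps the one that bears most on it is a 3.2-fold higher number from compound 1 to compound 3 (0.50 log units; beyond the scatter), read in reverse. Compound 2, with its 4-cyano-2-fluorophenyl, is less closely related, yet a 6.3-fold higher number from compound 2 to compound 3 (0.80 log units; beyond the scatter) points the same way.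

Compound 4 is therefore expected to give a lower number than compound 3 in this assay, with the step of a 2.5-fold lower number from compound 3 to compound 4 (0.40 log units; beyond the scatter) judged modest because a 3.2-fold higher number from compound 1 to compound 3 (0.50 log units; beyond the scatter) was modest. Compound 4 is estimated at 160 nM, within a range from 50 nM to 500 nM.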

Compound 4, half-maximal effective concentration: 501 nM
For compound 4 the middle estimate is 3.1-fold (0.50 log units) below the measured one, outside the stated range (above it).
By their numbers in this assay, from the lowest: compounds 2 and 1 (each within the scatter of the next); then compounds 3 and 4 (each within the scatter of the next).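

In this assay, carrying a sulfur and an oxygen on the aromatic ring proved no guarantee of staying near the 4-(methylsulfonyl)phenyl compound: the change on an aromatic carbon alone gave a 4.0-fold higher number from compound 1 to compound 4 (0.60 log units; beyond the scatter) and was beyond the scatter. At this nitrogen-linked position, compound 4 instead falls level with the nitrile compound, with a 1.3-fold higher number from compound 3 to compound 4 (0.10 log units; within the scatter) inside the scatter, and a 7.9-fold higher number from compound 2 to compound 4 (0.90 log units; beyond the scatter) is the largest step among the four compounds, so small changes in this group can separate compounds clearly, while the sulfur-bearing group and the 4-cyano-3-fluorophenyl group cannot be told apart here. No measurement is at hand that accounts for the gap between compound 1 and compound 4.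

The compounds shown leave open whether a dimethylsulfamoyl group, a primary carboxamide or a carboxylic acid on that aromatic carbon would stay near compound 1 or near compound 4. They also leave open whether adding a fluorine to the ring of compound 4 would shift its number, as moving the fluorine did between the two nitriles.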